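This account rests on a few compounds, and the source may have more. Where it says the series, first, only, none or still open, it means among the compounds named here.

Working notes on the series. Compound 3 `Cc1ccc(COc2c(-c3ccccc3)oc3cc(O)cc(O)c3c2=O)cc1` gives 40000 nM in an ADME assay on Huh-5-2 cells (Homo sapiens) for cytotoxicity, read by WST assay, with a stated time of 3 days (a higher number here means that more compound is tolerated, a lower number that less compound is tolerated), the second highest of the three numbers; compound 2 `O=c1c(OCc2ccc(Cl)cc2)c(-c2ccccc2)oc2cc(O)cc(O)c12` gives 36000 nM, and compound 1 `O=c1c(OCc2cccc(Cl)c2)c(-c2ccccc2)oc2cc(O)cc(O)c12` gives 46000 nM. All three sit close together: a 1.1-fold higher number from compound 2 to compound 3 (0.05 log units; within the scatter), a 1.2-fold lower number from compound 1 to compound 3 (0.06 log units; within the scatter) and a 1.3-fold lower number from compound 1 to compound 2 (0.11 log units; within the scatter). Compound 4 `COc1ccc(COc2c(-c3ccccc3)oc3cc(O)cc(O)c3c2=O)cc1` carries methoxy in place of methyl on an aromatic carbon. The step bearing most directly on it is the one at the same aromatic carbon, methyl in place of chloro, a 1.1-fold higher number from compound 2 to compound 3 (0.05 log units; within the scatter), and the other substituent exchanges on that benzyl ring were no larger. A further exchange at this position is therefore expected to stay within the scatter in this assay, with no direction to it: no change at the digits printed from compound 3 to compound 4 (within the scatter). Compound 4 is estimated at 40000 nM, between 20000 nM and 80000 nM.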

Compound 4, half-maximal cytotoxic concentration: 57000 nM
For compound 4 the middle estimate is 1.4-fold (0.15 log units) below the measured one, within the range that was stated.
By their numbers in this assay, from the lowest: compounds 2, 3, 1 and 4 (each within the scatter of the next).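

In this assay methoxy, which brings a hydrogen-bond acceptor to this aromatic carbon, still leaves the number within the scatter of methyl (a 1.4-fold higher number from compound 3 to compound 4 (0.15 log units; within the scatter)) and of chloro (a 1.6-fold higher number from compound 2 to compound 4 (0.20 log units; within the scatter)). Within the data shown here, the step from chloro is the largest so far, yet the whole set of substituents remains within the scatter, including the exchange involving 3-chlorophenyl (a 1.2-fold higher number from compound 1 to compound 4 (0.09 log units; within the scatter)). No independent data bear on these small differences.

From the compounds shown here alone, whether an amine, a carboxylic acid or a longer chain at this aromatic carbon would move the number beyond the scatter stays open.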